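The compounds below may be only part of what the source reports. "The series", "measured", "known", "first", "only" and "open" are said of these compounds alone.

Compound 1 (`CCCCCCCO[C@@H]1[C@@H](O)[C@@H](OCc2ccccc2)O[C@H](CO)[C@H]1O`) is the reference point in a functional assay on MCF7 cells (Homo sapiens) for cytotoxicity, in the presence of a further agent that is not named here; on this read-out lower numbers stand for an effect already at smaller amounts and higher numbers for an effect only at larger amounts of compound. Compound 1 is reported there as > 20 ug/mL, which is a limit of the assay and not a number.

Two relatives, both with larger groups on the shared core, do give numbers in this assay: compound 2 (`CCCCCCCO[C@@H]1[C@@H](O)[C@@H](OCc2ccccc2)O[C@@H]2CO[C@@H](c3ccc(OC)cc3)O[C@@H]12`) gives 2.5 ug/mL and compound 3 (`CCCCCCCO[C@@H]1[C@@H](OCc2ccccc2)[C@@H](OCc2ccccc2)O[C@H](CO)[C@H]1OCc1ccc(OC)cc1`) gives 3 ug/mL, two values within the usual scatter of each other.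

Compound 4 (`CCCCCCCO[C@@H]1[C@@H](O)[C@@H](OCc2ccccc2)O[C@H](CC(C)C)[C@H]1O`) departs from compound 1 in one place: isopropyl in place of hydroxy on a saturated chain carbon bound to a saturated ring carbon. This puts isopropyl in place of hydroxy on a saturated chain carbon bound to a saturated ring carbon, which also reads as hydroxymethyl to isobutyl.

Going by the values given here, no measured pair isolates this change, so the expectation rests on the numbers of compounds 2 and 3 alone. Compound 4 keeps the other free hydroxy groups of compound 1, so the expected shift is toward lower numbers but may fall short of those two values, and a further limit remains possible. The expected step is an at least 2.0-fold lower number from compound 1 to compound 4 (0.30 log units; that floor lies within the scatter). For compound 4 the estimate is 10 ug/mL, with an expected range of 4 ug/mL to 25 ug/mL.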

Compound 4, half-maximal effective concentration: 6 ug/mL
For compound 4 the middle estimate is 1.7-fold (0.22 log units) above the measured one; low and high end bracket the measured number.
By their numbers in this assay, from the lowest: compounds 2, 3 and 4 (each within the scatter of the next, the first and the last beyond it). At a limit, above all of these: compound 1.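

In this assay, going by these compounds alone, the change from hydroxymethyl to isobutyl on a saturated chain carbon bound to a saturated ring carbon gives an at least 3.3-fold lower number from compound 1 to compound 4 (0.52 log units; beyond the scatter), the first one-place evidence that this position alone can shift the read-out. The other free hydroxy groups of compound 1 remain in compound 4, so the larger groups elsewhere on the shared core in compounds 2 and 3 are not needed to obtain a number. The true size of the step remains unknown because the value of compound 1 is a limit of the assay and not a number: the limit of > 20 ug/mL in this assay, at which 1 of the 4 values shown sits.

This single pair cannot separate the loss of the hydroxy from the gain of the isopropyl. The compounds shown also leave open how an amine, a carboxylic acid or a longer chain would read at this place.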